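Swapping the basic amine tail on a shared core

A few compounds are considered here, and "the series" means these few. Any claim that something is new, unique, unknown or untested is made for them only; others in the source may bear on it.

Compound 1 `CCN(CC)CCCOc1cc2ncnc(Nc3nc4ccc(C(=O)Nc5c(C)cccc5Cl)cc4s3)c2cc1OC`: 9600 nM
Compound 2 `CCN(CC)CCCOc1cc2ncnc(Nc3nc4ccc(C(=O)Nc5c(C)cc(C)cc5C)cc4s3)c2cc1OC`: 6800 nM

In a functional assay on K562 cells (Homo sapiens) for cytotoxicity, read by WST assay, with a stated time of 72 h (on this read-out lower numbers stand for stronger inhibition and higher numbers for weaker inhibition), compound 1 gives 9600 nM and compound 2 gives 6800 nM. Within the data shown here, the only measured step, a 1.4-fold lower number from compound 1 to compound 2 (0.15 log units; within the scatter), is within the scatter, so compound 2 and compound 1 cannot be told apart on these numbers; compound 2 simply stands beside compound 1.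

Compound 3 `COc1cc2c(Nc3nc4ccc(C(=O)Nc5c(C)cc(C)cc5C)cc4s3)ncnc2cc1OCCCN1CCCC1` differs from compound 2 in one place: pyrrolidin-1-yl in place of diethylamino on a saturated chain carbon, three bonds along the chain from an oxygen on an aromatic ring. Among the measured compounds shown here, no measured step touches this part of the molecule; the one measured step concerns the amide side of the shared core and says nothing about the amine tail. Without a measured step on this change, the plain expectation is no step beyond the scatter in this assay, and compound 3 is therefore estimated to give 6800 nM, with a range from 2700 nM to 17000 nM, which would mean an expected step of no change at the digits printed from compound 2 to compound 3 (within the scatter).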

Compound 3, half-maximal inhibitory concentration: 4300 nM
Compound 3: the middle estimate sits 1.6-fold (0.20 log units) above what was measured; measured number inside the range.
By their numbers in this assay, from the lowest: compounds 3, 2 and 1 (each within the scatter of the next, the first and the last beyond it).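

Among these compounds, this is the first measured step on the amine tail: with the same count of heavy atoms leaving and entering, pyrrolidin-1-yl in place of diethylamino gives a 1.6-fold lower number from compound 2 to compound 3 (0.20 log units; within the scatter) in this assay. The step lies within the scatter, so compound 2 and compound 3 cannot be told apart, and tying the open diethylamino group into a five-membered ring shows no readable effect at this position in this assay. No supporting data bear on why the two compounds read alike.

Still open, from the compounds shown here alone, is whether another amine on the same chain, such as piperidin-1-yl or morpholin-4-yl, would give a step beyond the scatter. Also open, going by these compounds, is whether a shorter tail, such as 2-(pyrrolidin-1-yl)ethyl in place of 3-(pyrrolidin-1-yl)propyl, would do so.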